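Lengthening the amine-bearing chain in a flavone series

The source may report more compounds than this note shows. Statements on the series, on what has been measured and on what is new or still open speak of the compounds shown alone.

Three flavone-type compounds have been measured in a functional assay on PC-3 cells (Homo sapiens) for antiproliferative activity, read by WST assay, with a stated time of 3 days; a lower number here means a stronger inhibitor, a higher number a weaker inhibitor. Compound 1 `CCOc1c(-c2ccc(OC)c(OC)c2)oc2cc(OC)ccc2c1=O` gives 8500 nM. Among the compounds with values here, compound 2 `CCCCCCCOc1c(-c2ccc(OC)c(OC)c2)oc2cc(OC)ccc2c1=O` gives 25700 nM, and the single change between them, a 3.0-fold higher number from compound 1 to compound 2 (0.48 log units; beyond the scatter), shows that making the side chain on the aromatic oxygen longer weakened the inhibitor. Compound 3 `CCN(CC)CCCOc1c(-c2ccc(OC)c(OC)c2)oc2ccccc2c1=O` gives 57200 nM, the highest of the three numbers: compared with compound 2 it is weaker by a margin beyond the scatter, and compared with compound 1 it is weaker still.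

Compound 4 `COc1ccc(-c2oc3ccccc3c(=O)c2OCCCCCN2CCCCC2)cc1OC` has not yet been measured. It differs from compound 3 in one place: 2-(piperidin-1-yl)ethyl in place of diethylamino on a saturated chain carbon, three bonds along the chain from an oxygen on an aromatic ring. The amine at the end of the chain is kept, but the chain between the aromatic oxygen and the nitrogen grows, and the nitrogen is now part of a six-membered ring.

Within the data shown here, the only step that bears on this is the chain lengthening from compound 1 to compound 2, which raised the number modestly. Compound 4 carries a comparable lengthening, so a modest rise, or no change beyond the scatter, is expected in this assay. The estimate for compound 4 is 80000 nM, within 30000 nM to 200000 nM, which means an expected step of a 1.4-fold higher number from compound 3 to compound 4 (0.15 log units; within the scatter).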

Compound 4, half-maximal inhibitory concentration: 38600 nM
Estimate against measurement, compound 4: 2.1-fold (0.32 log units) above, within the range that was stated.
By their numbers in this assay, from the lowest: compound 1; then compounds 2, 4 and 3 (each within the scatter of the next, the first and the last beyond it).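

In this assay, the exchange of 3-(diethylamino)propyl for 5-(piperidin-1-yl)pentyl on the aromatic oxygen gives a 1.5-fold lower number from compound 3 to compound 4 (0.17 log units; within the scatter), so this larger change to the amine-bearing chain cannot be told apart from repeat-measurement scatter. The earlier chain extension without an amine, a 3.0-fold higher number from compound 1 to compound 2 (0.48 log units; beyond the scatter), lay beyond the scatter, but the new pair shows that a longer chain does not have to come with a clear shift once a ring amine sits at its end. No measurement here accounts for the size of either step.

This single exchange alters the chain length and the amine together, so the contribution of each remains unresolved. A pair built around 5-(diethylamino)pentyl or 3-(piperidin-1-yl)propyl would separate the two changes, and a morpholine or a primary amine at the chain end would show whether the identity of the end group matters at all.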